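Swapping Butyl for Cyclopentyl on the Shared Core

This account rests on a few compounds, and the source may have more. Where it says the series, first, only, none or still open, it means among the compounds named here.

Of the compounds shown here, two have so far been measured in a functional assay on HepG2 cells (Homo sapiens) for antiproliferative activity, read by CCK-8 assay, with a stated time of 72 h, tested at 2 uM; a higher number here means a stronger effect of the compound at the concentration tested, a lower number a weaker effect. Compound 1, `CCCCn1cnc2c(Nc3cccc(Cl)c3)nc(NCOCc3ccc(/C=C/C(=O)Nc4ccccc4N)cc3)nc21`, gives 20.5% in this assay. Compound 2, `Nc1ccccc1NC(=O)/C=C/c1ccc(Cn2cnc3c(Nc4cccc(Cl)c4)nc(Cl)nc32)cc1`, gives 35.8% in this assay. Of these two numbers compound 1 stands lowest; compound 2 differs from it in more than one place, so the two values are only shown side by side and no single structural step joins them.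

Compound 3, `Nc1ccccc1NC(=O)/C=C/c1ccc(COCNc2nc(Nc3cccc(Cl)c3)c3ncn(C4CCCC4)c3n2)cc1`, has not yet been measured. It differs from compound 1 in one place: cyclopentyl in place of butyl on an aromatic nitrogen. Both groups are carbon only and sit on the same aromatic nitrogen of the five-membered aromatic ring with 2 nitrogen in the fused system.

Going by the values given here, no measured pair shows the effect of such a change, so the expectation rests on the closeness of the two groups alone. The step from compound 1 to compound 3 is expected to be small, a number 3.5 percentage points higher from compound 1 to compound 3 (within the scatter), in no particular direction and within the usual scatter. Compound 3 is therefore estimated to give 24% in this assay, with a range from 8% to 42%.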

Compound 3, a percentage reported as inhibition, at one concentration (the size of the read-out at that concentration, not a potency): 9.67%
Compound 3: the middle estimate sits 14.3 percentage points above what was measured; the range from low to high includes it.
By their numbers in this assay, from the lowest: compound 3; then compound 1; then compound 2.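

In this assay, the group on this aromatic nitrogen proves able to shift the read-out: cyclopentyl in place of butyl gives a number 10.8 percentage points lower from compound 1 to compound 3 (beyond the scatter), a modest step and the first single change read at this position. Both groups are carbon only and have no hydrogen-bond donors or acceptors, so the step separates butyl, with 4 heavy atoms and no ring, from cyclopentyl, with 5 heavy atoms and one five-membered non-aromatic ring of carbon only. Nothing measured on either group bears on this result, and the data offer no explanation for it.

This single step leaves open whether the lower number goes with the ring or with the added carbon, a question that a cyclobutyl group, an isopropyl group or a longer chain such as pentyl on the same nitrogen could help to settle. Also open, as far as these compounds go, is how a group holding atoms other than carbon, such as a methoxyethyl chain or an amine, would read at this position.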